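The source may report more compounds than this note shows. Statements on the series, on what has been measured and on what is new or still open speak of the compounds shown alone.

Compound 3 `CCOC(=O)Nc1nc2ccc(NC(=O)c3c(Cl)cccc3Cl)cc2s1` gives the lowest number of the three in a functional assay on WI-38 VA13 cells (Homo sapiens) for cytotoxicity (on this read-out higher numbers stand for an effect only at larger amounts of compound and lower numbers for an effect already at smaller amounts), with compound 3 at 0.0026 ug/mL; compound 2 `CC(C)CC(=O)Nc1nc2ccc(NC(=O)c3c(Cl)cccc3Cl)cc2s1` stands nearest at 0.012 ug/mL, and compound 1 `Cc1cccc(C)c1NC(=O)Nc1ccc2nc(NC(=O)C3CCCCC3)sc2c1`, which differs from the other two at two places, stands furthest at 0.56 ug/mL.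

The step to compound 4 `COc1cccc(Nc2nc3ccc(NC(=O)c4c(Cl)cccc4Cl)cc3s2)c1` is 3-methoxyphenyl in place of ethoxycarbonyl on a nitrogen on an aromatic ring. For the measured compounds named here, the only single-place step measured in this assay touches the same nitrogen: a 4.6-fold lower number from compound 2 to compound 3 (0.66 log units; beyond the scatter), a modest change for a swap of two small groups on a carbonyl carbon. Going by the values given here, the change to compound 4 is larger in kind, since the carbonyl is lost and an aromatic ring enters, and no measured pair covers such an exchange. The expectation is therefore wide: a shift in this assay somewhat beyond the scatter, more likely toward a higher number than toward a lower one, is expected, with the carbamate of compound 3 at 0.0026 ug/mL as the anchor.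

For compound 4 the estimated value in this assay is 0.02 ug/mL, with a range of 0.003 ug/mL to 0.15 ug/mL, meaning an expected step of a 7.7-fold higher number from compound 3 to compound 4 (0.89 log units; beyond the scatter).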

Compound 4, half-maximal effective concentration: > 7.2 ug/mL
Compound 4 ended at the assay's limit (the forecaster's own chance of this, stated with the estimate: 5%); middle value at least 360-fold (2.55 log units) from the limit.
By their numbers in this assay, from the lowest: compound 3; then compound 2; then compound 1. At a limit, above all of these: compound 4.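

In this assay compound 4 is read only as a limit of the assay, not as a number: the limit of > 7.2 ug/mL in this assay, at which 1 of the 4 values shown sits.

The nitrogen on an aromatic ring proves far more sensitive to the kind of group it carries than the earlier pair suggested: the swap that kept the carbonyl gave only a 4.6-fold lower number from compound 2 to compound 3 (0.66 log units; beyond the scatter). Replacing the carbonyl-bearing group with 3-methoxyphenyl gives an at least 2700-fold higher number from compound 3 to compound 4 (3.44 log units; beyond the scatter), and the comparison with the isobutylcarbonyl compound gives an at least 600-fold higher number from compound 2 to compound 4 (2.77 log units; beyond the scatter), both large.

The compounds shown do not separate the loss of the carbonyl from the entry of the 3-methoxyphenyl ring, and either could account for the step. A free amine, a benzoyl group or an unsubstituted phenyl on this nitrogen would help to tell these two apart.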